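The source may report more compounds than this note shows. Statements on the series, on what has been measured and on what is new or still open speak of the compounds shown alone.

Compounds measured so far:

Compound 1, `CCOc1ccc(-c2nn3cc(-c4cccc(N)c4)nc3s2)cc1`: 94000 nM
Compound 2, `C=C(Br)C(=O)Nc1cccc(-c2cn3nc(-c4ccc(OCC)cc4)sc3n2)c1`: 1100 nM
Compound 3, `C=C(Br)C(=O)Nc1cccc(-c2cn3c(-c4ccc(OC)cc4)csc3n2)c1`: 860 nM

Compound 2 sits second highest of the three numbers in a functional assay on HeLa cells (Homo sapiens) for inhibition, read by cell counting, with a stated time of 4 days; a lower number here means a stronger inhibitor, a higher number a weaker inhibitor. Its nearest neighbour is compound 3, whose value of 860 nM lies within the scatter of compound 2; its furthest is compound 1, separated from it by a step beyond the scatter.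

Within the data shown here, the only measured step that involves compound 2 is an 85-fold lower number from compound 1 to compound 2 (1.93 log units; beyond the scatter), which attaches a (1-bromoethenyl)carbonyl group to the ring nitrogen; it is a large change, but it is not the change studied here.

Compound 4, `C=C(Br)C(=O)Nc1cccc(-c2cn3nc(-c4ccc(OC)cc4)sc3n2)c1`, has not yet been measured. It differs from compound 2 by hydrogen in place of methyl on a saturated chain carbon bound to an oxygen on an aromatic ring. Among the measured compounds shown here, no measured pair isolates this change, so nothing directly tells how an ethoxy-to-methoxy swap shifts the number. Compound 3 carries the methoxy group, but its core differs from that of compound 2 as well, so its value only shows that a methoxy-bearing analogue lands near compound 2. On that basis a step of a 1.1-fold lower number from compound 2 to compound 4 (0.04 log units; within the scatter) is expected, that is, no shift beyond the scatter. Compound 4 is therefore estimated at 1000 nM in this assay, with a range of 400 nM to 2500 nM.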

Compound 4, half-maximal inhibitory concentration: 2300 nM
Estimate against measurement, compound 4: 2.3-fold (0.36 log units) below, within the range that was stated.
By their numbers in this assay, from the lowest: compounds 3 and 2 (each within the scatter of the next); then compound 4; then compound 1.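

In this assay, among these compounds, compounds 2 and 4 differ only in the group on the oxygen of the aromatic ring, so this pair gives the only direct reading of the change from ethoxy to methoxy, and it shows a 2.1-fold higher number from compound 2 to compound 4 (0.32 log units; beyond the scatter) on removal of one methyl. The earlier compounds shown here could not show this, and the pair shows that this end of the molecule is not indifferent to a small edit: the loss of a single carbon moves the number beyond the scatter, although only modestly, and here the ethoxy compound is the stronger inhibitor of the two. Nothing measured here explains this shift.

On these data alone, with only ethoxy and methoxy to compare at this position, it remains open whether a longer chain such as propoxy or butoxy would lower the number further, or whether a branched isopropoxy group or a plain hydroxy group would raise it. It is also open whether the same swap would act in the same way on the core of compound 3, which carries methoxy and has no ethoxy partner among the compounds shown.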